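Adding isopropoxy to compound 3

This account rests on a few compounds, and the source may have more. Where it says the series, first, only, none or still open, it means among the compounds named here.

Values in an ADME assay on MIA PaCa-2 cells (Homo sapiens) for cytotoxicity, read by MTT assay, with a stated time of 72 h (a lower number here means a stronger inhibitor, a higher number a weaker inhibitor), all three of them limits and not numbers:
- Compound 1 `COc1ccc(C2=C(c3cc(OC)c(OC)c(OC)c3)C(=O)C(OC(C)=O)C2)cc1OC(C)C` gives > 100 ug/mL (a limit)
- Compound 2 `COc1ccc(C2=C(c3cc(OC)c(OC)c(OC)c3)C(=O)C(OC(C)=O)C2)cc1` gives < 1 ug/mL (a limit)
- Compound 3 `COc1ccc(C2=C(c3cc(OC)c(OC)c(OC)c3)C(=O)C(O[SiH2]C(C)(C)C)C2)cc1` gives < 1 ug/mL (a limit)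

Compound 3 holds only a limit (< 1 ug/mL) in this assay and no number. Compound 4 `COc1ccc(C2=C(c3cc(OC)c(OC)c(OC)c3)C(=O)C(O[SiH2]C(C)(C)C)C2)cc1OC(C)C` carries one change (isopropoxy in place of hydrogen on an aromatic carbon), isopropoxy in place of hydrogen on an aromatic carbon. The same exchange, run the opposite way, was measured as an at least 100-fold lower number from compound 1 to compound 2 (2.00 log units; beyond the scatter) and is large, beyond the scatter. The other measured step is a step that the two limits leave unreadable from compound 2 to compound 3 and gives no size. A large move towards a higher number, a weaker inhibitor, is therefore expected. The expected change for compound 4 is an at least 40-fold higher number from compound 3 to compound 4 (1.60 log units; beyond the scatter) on this single precedent. Compound 4 is estimated at 40 ug/mL with a range from 4 ug/mL to 150 ug/mL in this expectation.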

Compound 4, half-maximal inhibitory concentration: > 100 ug/mL
Compound 4: no number, only a limit (the forecaster's own chance of this, stated with the estimate: 55%); middle value at least 2.5-fold (0.39 log units) from the limit.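

In this assay, isopropoxy in place of hydrogen on the aromatic carbon ortho to a methoxy group gives an at least 100-fold higher number from compound 3 to compound 4 (2.00 log units; beyond the scatter). The large loss is therefore not confined to one group on the oxygen on a saturated carbon, and the change repeats on a second core: the same change on two cores in this assay, an at least 100-fold lower number (2.00 log units; beyond the scatter) from compound 1 to compound 2 and an at least 100-fold lower number (2.00 log units; beyond the scatter) from compound 4 to compound 3; the limit leaves it open whether they differ The steps that join two limits of the same kind cannot be read, so nothing can be said about the exchange on that oxygen. As far as these compounds go, it remains open how a hydroxyl, ethoxy or an amine at this place would read in this assay. From the compounds shown here alone, the true size of the step also stays open.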